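Swapping the acyl group on a shared triazene core

A few compounds are considered here, and "the series" means these few. Any claim that something is new, unique, unknown or untested is made for them only; others in the source may bear on it.

Compound 2 `O=C(c1cccc(C(F)(F)F)c1)N(/N=N/c1ccc([N+](=O)[O-])cc1Br)c1ccc([N+](=O)[O-])cc1Br` gives 1120 nM in a functional assay on HeLa cells (Homo sapiens) for cytotoxicity, read by MTT assay, with a stated time of 72 h (a higher number here means a weaker inhibitor, a lower number a stronger inhibitor), the higher of the two numbers measured, while compound 1 `CC(=O)N(/N=N/c1ccc([N+](=O)[O-])cc1Br)c1ccc([N+](=O)[O-])cc1Br` gives 550 nM. The step of a 2.0-fold higher number from compound 1 to compound 2 (0.31 log units; beyond the scatter) is the only measured one. Compound 3 `CC(=O)OCC(=O)N(/N=N/c1ccc([N+](=O)[O-])cc1Br)c1ccc([N+](=O)[O-])cc1Br` differs from compound 2 by acetoxymethyl in place of 3-(trifluoromethyl)phenyl on a carbonyl carbon. That single step accompanied moving from methyl to 3-(trifluoromethyl)phenyl, and acetoxymethyl is, like methyl, a chain with no ring, so the number is expected to move back toward compound 1. Because compound 1 gave 550 nM, compound 3 is expected to give 700 nM, within 300 nM to 1600 nM, which would mean a 1.6-fold lower number from compound 2 to compound 3 (0.20 log units; within the scatter).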

Compound 3, half-maximal inhibitory concentration: 490 nM
Compound 3: the middle estimate sits 1.4-fold (0.15 log units) above what was measured; measured number inside the range.
By their numbers in this assay, from the lowest: compounds 3 and 1 (each within the scatter of the next); then compound 2.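

In this assay acetoxy in place of hydrogen on the chain gives a 1.1-fold lower number from compound 1 to compound 3 (0.05 log units; within the scatter) here, so the two compounds cannot be told apart at this position. Acetoxymethyl in place of 3-(trifluoromethyl)phenyl gives a 2.3-fold lower number from compound 2 to compound 3 (0.36 log units; beyond the scatter) in the same test, so the two compounds with no ring on the carbonyl carbon sit together and compound 2 stands apart. No measurement here explains that difference. Still open, on these data alone, is whether the ring itself or its trifluoromethyl goes with the higher number, which plain phenyl would help to separate. As far as these compounds go, how an amine or a longer chain would behave at this place also stays open.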